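The source may hold more compounds than are shown below. What is called first, only, known or untested is meant among the compounds shown, and "the series" means these compounds.

Three amides sharing one core have been measured. Compound 1 `CCN1CCN(c2cc(C)c3cc(NC(=O)c4cccc(Cl)c4)ccc3n2)CC1` gives 17800 nM in a functional assay on SK-BR-3 cells (Homo sapiens) for antiproliferative activity, read by MTT assay, with a stated time of 72 h; on this read-out lower numbers stand for stronger inhibition and higher numbers for weaker inhibition. Compound 2 `CCN1CCN(c2cc(C)c3cc(NC(=O)c4ccc(OC)cc4)ccc3n2)CC1` gives 9000 nM in that assay, and compound 3 `CCN1CCN(c2cc(C)c3cc(NC(=O)c4cccc(F)c4)ccc3n2)CC1` gives 24900 nM in that assay. Compound 3 carries the highest of the three numbers; the gap to compound 1, a 1.4-fold higher number from compound 1 to compound 3 (0.15 log units; within the scatter), is within the scatter, while the gap to compound 2 is read as a 2.8-fold higher number from compound 2 to compound 3 (0.44 log units; beyond the scatter).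

Compound 4 `CCN1CCN(c2cc(C)c3cc(NC(=O)c4ccccc4OC)ccc3n2)CC1` has not been measured. The change from compound 3 is 2-methoxyphenyl in place of 3-fluorophenyl on a carbonyl carbon. Going by the values given here, two measured steps bear on it. Among the compounds with values here, the methoxy series so far holds only a 4-methoxyphenyl: from compound 1 to compound 2 the step was a 2.0-fold lower number from compound 1 to compound 2 (0.30 log units; within the scatter), and the step of a 2.8-fold higher number from compound 2 to compound 3 (0.44 log units; beyond the scatter) sets the 3-fluorophenyl against that same 4-methoxyphenyl. Whether a 2-methoxyphenyl behaves like the 4-methoxyphenyl is not shown by any compound here, so the direction is taken from the one methoxy case with a wide range. A modest move to a lower number is expected, a 2.1-fold lower number from compound 3 to compound 4 (0.32 log units; beyond the scatter), on the strength of the step of a 2.8-fold higher number from compound 2 to compound 3 (0.44 log units; beyond the scatter). For compound 4 the expected value in that assay is 12000 nM, within a range from 5000 nM to 30000 nM.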

Compound 4, half-maximal inhibitory concentration: 15700 nM
Estimate against measurement, compound 4: 1.3-fold (0.12 log units) below, and the stated range covers the measured number.
By their numbers in this assay, from the lowest: compounds 2, 4, 1 and 3 (each within the scatter of the next, the first and the last beyond it).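

In this assay, the 2-methoxyphenyl on the carbonyl carbon cannot be separated from either halogen-bearing group, with a 1.6-fold lower number from compound 3 to compound 4 (0.20 log units; within the scatter) against the 3-fluorophenyl and a 1.1-fold lower number from compound 1 to compound 4 (0.05 log units; within the scatter) against the 3-chlorophenyl. Going by these compounds alone, it also cannot be separated from the other methoxy group, since a 1.7-fold higher number from compound 2 to compound 4 (0.24 log units; within the scatter) is the first comparison of 2-methoxyphenyl with 4-methoxyphenyl, so these two compounds show no dependence on where the methoxy group stands; the only step among the four compounds that lies beyond the scatter remains a 2.8-fold higher number from compound 2 to compound 3 (0.44 log units; beyond the scatter), and compound 4 falls within the scatter of both of those compounds. Nothing available here accounts for these numbers or for the absence of a separation at this position.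

Still open, as far as these compounds go, is whether any group on this carbonyl carbon moves the number well outside the band these four compounds occupy, for example a benzene ring carrying a carboxylic acid or a dimethylamino group, or a saturated ring or alkyl chain in place of the benzene ring. From the compounds shown here alone, every compound here also keeps the shared core unchanged, so what a change elsewhere in that core would do remains unknown.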